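Replacing the 3-chloro-4-methylphenyl group of compound 2

The source may report more compounds than this note shows. Statements on the series, on what has been measured and on what is new or still open speak of the compounds shown alone.

Compound 1 `Cc1ccc(NC(=O)Nc2cccc(-c3cccc4[nH]nc(N)c34)c2)cc1`: 4450 nM
Compound 2 `Cc1ccc(NC(=O)Nc2cccc(-c3cccc4[nH]nc(N)c34)c2)cc1Cl`: 510 nM

In a functional assay on SMMC-7721 cells (Homo sapiens) for inhibition, read by MTT assay, with a stated time of 48 h (on this read-out higher numbers stand for weaker inhibition and lower numbers for stronger inhibition), compound 2 holds the lower of the two numbers, at 510 nM. Compound 3 `Nc1n[nH]c2cccc(-c3cccc(NC(=O)Nc4cccc(F)c4)c3)c12` carries 3-fluorophenyl in place of 3-chloro-4-methylphenyl on an amide-type nitrogen. Among the compounds with values here, the one measured step that bears on this is an 8.7-fold lower number from compound 1 to compound 2 (0.94 log units; beyond the scatter), where chloro replaced hydrogen on an aromatic carbon. On these data alone, compound 3 has no chloro, so part of that step is expected to be given back, though the fluoro group is untested here. The expected change is a 3.5-fold higher number from compound 2 to compound 3 (0.55 log units; beyond the scatter). For compound 3 the estimated value is 1800 nM, with an expected range from 500 nM to 6000 nM.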

Compound 3, half-maximal inhibitory concentration: 1240 nM
For compound 3 the middle estimate is 1.5-fold (0.16 log units) above the measured one; low and high end bracket the measured number.
By their numbers in this assay, from the lowest: compound 2; then compound 3; then compound 1.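

In this assay, the aryl group on the amide-type nitrogen tolerates more than one substitution pattern. Moving to 3-fluorophenyl costs something against 3-chloro-4-methylphenyl, with a 2.4-fold higher number from compound 2 to compound 3 (0.39 log units; beyond the scatter), yet it still gains over 4-methylphenyl, with a 3.6-fold lower number from compound 1 to compound 3 (0.55 log units; beyond the scatter), so chloro is not the only change that lowers the number relative to compound 1. No measurement given here offers an explanation for these steps.

The compounds shown leave open how much of that gain belongs to fluoro and how much to the loss of methyl. They also leave open how a trifluoromethyl or methoxy group on this phenyl ring would compare.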